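Methoxy to Ethyl on the Pyrimidine of Compound 2

The source may hold more compounds than are shown below. What is called first, only, known or untested is meant among the compounds shown, and "the series" means these compounds.

Measured compounds:
compound 1 `COc1ncc(-c2nc(C(F)(F)F)sc2N2CCN(C(=O)Cn3cnc4cccnc43)[C@H](C)C2)cn1`, 177 nM
compound 2 `COc1ncc(-c2nc(C(F)(F)F)sc2N2CCN(C(=O)Cn3nc(C)nc3C)[C@H](C)C2)cn1`, 558 nM

Compound 1 `COc1ncc(-c2nc(C(F)(F)F)sc2N2CCN(C(=O)Cn3cnc4cccnc43)[C@H](C)C2)cn1` and compound 2 `COc1ncc(-c2nc(C(F)(F)F)sc2N2CCN(C(=O)Cn3nc(C)nc3C)[C@H](C)C2)cn1` share a core and differ only in the group on the saturated chain carbon next to the carbonyl. In a functional assay on U2OS cells for antagonist activity at C-X-C chemokine receptor type 3 (Homo sapiens), read by beta-arrestin recruitment (on this read-out higher numbers stand for weaker inhibition and lower numbers for stronger inhibition), compound 1 gives 177 nM, and compound 2 gives 558 nM; the step of a 3.2-fold higher number from compound 1 to compound 2 (0.50 log units; beyond the scatter) puts compound 2 at the higher of the two numbers shown, so far the weaker of the pair.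

Compound 3 `CCc1ncc(-c2nc(C(F)(F)F)sc2N2CCN(C(=O)Cn3nc(C)nc3C)[C@H](C)C2)cn1` keeps the whole of compound 2 except for one change: ethyl in place of methoxy on an aromatic carbon. Among the measured compounds shown here, no measured step touches this position; the only step known, a 3.2-fold higher number from compound 1 to compound 2 (0.50 log units; beyond the scatter), concerns a different part of the molecule and gives no guide to the direction here. The change is therefore expected to leave the number of compound 3 near that of compound 2, with the step of a 1.0-fold higher number from compound 2 to compound 3 (0.00 log units; within the scatter) expected to lie within the scatter. Compound 3 is thus estimated at 560 nM in this assay, in the range 250 nM to 1300 nM.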

Compound 3, half-maximal inhibitory concentration: 1430 nM
For compound 3 the middle estimate is 2.6-fold (0.41 log units) below the measured one; measured number above the stated range.
By their numbers in this assay, from the lowest: compound 1; then compound 2; then compound 3.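

In this assay the carbon of the pyrimidine that lies between two ring nitrogen atoms and para to a large group proves responsive: going from 2-methoxypyrimidin-5-yl to 2-ethylpyrimidin-5-yl gives a 2.6-fold higher number from compound 2 to compound 3 (0.41 log units; beyond the scatter) and so moves the read-out towards weaker inhibition by more than the usual scatter. Methoxy and ethyl are equal in their count of heavy atoms, so the number at this position moves even though that count stays the same, while one oxygen gives way to one carbon and the hydrogen-bond acceptor of methoxy is lost. The information at hand gives no explanation for the size or direction of this step.

With only methoxy and ethyl on this carbon among the compounds shown, it remains open how an amine such as dimethylamino, a hydroxyl group or a longer chain such as propyl would read there. Going by these compounds, whether ethyl in place of methoxy would move the number by a similar amount with the group of compound 1 on the saturated chain carbon also stays open.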